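Thiol monomer versus disulfide pair in Fc receptor inhibition

The compounds below may be only part of what the source reports. "The series", "measured", "known", "first", "only" and "open" are said of these compounds alone.

Compound 1 `Cc1nn(-c2ccccc2)c(SSc2c(C(=O)c3ccccc3)c(C)nn2-c2ccccc2)c1C(=O)c1ccccc1` in an assay on isolated protein for inhibition of high affinity immunoglobulin gamma Fc receptor I (Homo sapiens), with stated times of 1 h and 2 h, tested at 5 uM (a lower number here means less inhibition, a higher number more inhibition at the concentration tested (going by the name of the read-out)), gives 22%. For the measured compounds named here, compound 2 `Cc1nn(-c2ccccc2)c(S)c1C(=O)c1ccno1` in this assay is reported as "not active" (no number reported), so compound 2 has no single number to stand on, and no step to another measured compound is available. Compound 3 `Cc1nn(-c2ccccc2)c(S)c1C(=O)c1ccccc1` differs from compound 2 by phenyl in place of 1,2-oxazol-5-yl on a carbonyl carbon. Compound 1 carries the same phenyl on a carbonyl carbon, and its reading is the only anchor. Without a measured step, only a small upward move is expected, hardly beyond the scatter. Compound 3 is estimated at 15% with a range of 0% to 35%.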

Compound 3, a percentage reported as inhibition, at one concentration (the size of the read-out at that concentration, not a potency): 0%
For compound 3 the middle estimate is 15 percentage points above the measured one; low and high end bracket the measured number.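

For the compounds shown here, no step from compound 2 to compound 3 can be read: compound 3 gives 0%, while compound 2 has no number. The compounds shown leave open what replacing 1,2-oxazol-5-yl with phenyl does to inhibition. No supporting evidence bears on this result.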